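Dimethylamino in place of sulfanyl on a fused triazine core

This account rests on a few compounds, and the source may have more. Where it says the series, first, only, none or still open, it means among the compounds named here.

The series shares a fused core carrying a benzyl chain. Compound 1 `O=c1[nH]c(=S)[nH]c2c(CCCCCOCc3ccccc3)ncn12`, which has a longer linker and a different core substitution, gives 259000 nM in a functional assay on CCRF-CEM cells (Homo sapiens) for cytotoxicity; a lower number here means that less compound is tolerated, a higher number that more compound is tolerated. Compound 2 `Sc1ncnc2c(Cc3ccccc3)ncn12` gives 35100 nM, and compound 3 `Cc1ccc(Cc2ncn3c(S)ncnc23)cc1` gives 32800 nM. Among the three numbers compound 2 stands second highest; it sits closest to compound 3, with a 1.1-fold lower number from compound 2 to compound 3 (0.03 log units; within the scatter) for methyl in place of hydrogen on an aromatic carbon, and furthest from compound 1.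

Compound 4 `CN(C)c1ncnc2c(Cc3ccccc3)ncn12` differs from compound 2 by dimethylamino in place of sulfanyl on an aromatic carbon. Within the data shown here, no measured step touches this position or this exchange; the only step available, from compound 2 to compound 3, changes a distant aromatic carbon and lies within the scatter, so it offers no guidance on direction. He therefore expects no step beyond the scatter for a 1.1-fold higher number from compound 2 to compound 4 (0.06 log units; within the scatter), with a wide range. His estimate for compound 4 is 40000 nM, between 10000 nM and 160000 nM.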

Compound 4, half-maximal cytotoxic concentration: > 790000 nM
Compound 4: only a limit was reported; the forecaster's own chance of this, stated with the estimate: 15%; middle value at least 19-fold (1.29 log units) away from the limit.
By their numbers in this assay, from the lowest: compounds 3 and 2 (each within the scatter of the next); then compound 1. At a limit, above all of these: compound 4.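

Dimethylamino in place of sulfanyl on this aromatic carbon, between two ring nitrogen atoms, shows that the shared core responds strongly to a change here: in this assay the exchange gives an at least 22-fold higher number from compound 2 to compound 4 (1.35 log units; beyond the scatter), whereas the methyl exchange gave a 1.1-fold lower number from compound 2 to compound 3 (0.03 log units; within the scatter). Among these compounds, of these two single exchanges, only the one at the sulfanyl position lies beyond the scatter. The reading for compound 4 is a limit of the assay and not a number: the limit of > 790000 nM in this assay, at which 1 of the 4 values shown sits.

The one exchange removes sulfanyl and brings in dimethylamino at once, and the compounds shown cannot tell which of the two carries the step. From the compounds shown here alone, how an unsubstituted amine, a methoxy group or a plain hydrogen at this position would read in this assay remains open, as does whether dimethylamino behaves the same alongside the methyl of compound 3.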